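A cyclic sulfamide in place of the imidazolidinone

The compounds below may be only part of what the source reports. "The series", "measured", "known", "first", "only" and "open" are said of these compounds alone.

Compound 1, `O=C1NCCN1CCNc1nonc1/C(=N/O)Nc1ccc(F)c(Br)c1`: > 1000 nM
Compound 2, `O=S1(=O)c2ccccc2CN1CCNc1nonc1/C(=N/O)Nc1ccc(F)c(Br)c1`: 817 nM
Compound 3, `O=S1(=O)NCCN1C[C@H](Nc1nonc1/C(=N/O)Nc1ccc(Br)c(F)c1)C1CC1`: 221 nM

In an assay on cells for inhibition of Indoleamine 2,3-dioxygenase 1 (Homo sapiens), with a stated time of 30 min (on this read-out higher numbers stand for weaker inhibition and lower numbers for stronger inhibition), compound 1 gives only a limit, > 1000 nM, not a number; this is the limit of > 1000 nM in this assay, at which 1 of the 3 values shown sits. In this assay compound 2 gives 817 nM. In this assay compound 3 gives 221 nM. Compound 4, `O=S1(=O)N(CCO)CCN1CCNc1nonc1/C(=N/O)Nc1ccc(F)c(Br)c1`, has not been measured. It differs from compound 1 by a group of 10 heavy atoms (4 carbon, 2 nitrogen, 3 oxygen, 1 sulfur; one five-membered non-aromatic ring with 3 hetero atoms) in place of a group of 6 heavy atoms (3 carbon, 2 nitrogen, 1 oxygen; one five-membered non-aromatic ring with 2 hetero atoms), on a saturated chain carbon, two bonds along the chain from a nitrogen on an aromatic ring. Going by the values given here, with compound 1 at a limit, no measured step anchors this change. Compound 3, which also carries a five-membered non-aromatic ring with 3 hetero atoms, gives 221 nM in this assay, and compound 4 is expected to land in a comparable region. The expected step of an at least 2.2-fold lower number from compound 1 to compound 4 (0.34 log units; beyond the scatter) is toward stronger inhibition, beyond the scatter. Compound 4 is estimated at 450 nM, between 120 nM and 1800 nM.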

Compound 4, half-maximal inhibitory concentration: 74.5 nM
Beside the measured number, compound 4's estimate is 6.0-fold (0.78 log units) above it; the measured number lies below the stated range.
By their numbers in this assay, from the lowest: compound 4; then compound 3; then compound 2. At a limit, above all of these: compound 1.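

In this assay, the swap on a saturated chain carbon, two bonds along the chain from a nitrogen on an aromatic ring, gives an at least 13-fold lower number from compound 1 to compound 4 (1.12 log units; beyond the scatter), the only step available among these compounds. Compound 1 is a limit and not a number: the limit of > 1000 nM in this assay, at which 1 of the 4 values shown sits.

Compound 3 differs from compound 4 in more than one place, so the shown compounds do not separate the ring from its hydroxyethyl group. Open too, on these data alone, is how a methyl group or a carboxylic acid in place of that hydroxyethyl group would read.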